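Chloro for Fluoro at the Edge of Measurement

A few compounds are considered here, and "the series" means these few. Any claim that something is new, unique, unknown or untested is made for them only; others in the source may bear on it.

Three compounds share one core and were tested in a functional assay on MCF7 cells (Homo sapiens) for inhibition, read by MTT assay, with a stated time of 72 h; a lower number here means a stronger inhibitor, a higher number a weaker inhibitor. Compound 1 `N#Cc1c(Nc2ccccc2Cl)nc(SCc2cn(Cc3ccccc3Cl)nn2)nc1-c1ccccc1` gives 1950 nM. Compound 2 `N#Cc1c(Nc2ccccc2F)nc(SCc2cn(Cc3ccccc3Cl)nn2)nc1-c1ccccc1` gives 8060 nM, and the step of a 4.1-fold higher number from compound 1 to compound 2 (0.62 log units; beyond the scatter) shows the cost of that swap. Compound 3 `Cc1ccc(Cn2cc(CSc3nc(Nc4ccccc4F)c(C#N)c(-c4ccccc4)n3)nn2)cc1` reaches only the assay limit, > 64000 nM, so it is not a number but a boundary; the limit of > 64000 nM in this assay, at which 1 of the 3 values shown sits, marks where it sits, and the step of an at least 7.9-fold higher number from compound 2 to compound 3 (0.89 log units; beyond the scatter) is therefore known only as a minimum.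

Compound 4 `Cc1ccc(Cn2cc(CSc3nc(Nc4ccccc4Cl)c(C#N)c(-c4ccccc4)n3)nn2)cc1` differs from compound 3 by one exchange: chloro in place of fluoro on an aromatic carbon. The same exchange, in the opposite direction, is the measured step from compound 1 to compound 2, where fluoro in place of chloro raised the number beyond the scatter. Running it backwards, chloro in place of fluoro is expected to lower the number in this assay by a comparable amount, so the estimated step is an at least 2.5-fold lower number from compound 3 to compound 4 (0.40 log units; beyond the scatter). Because compound 3 is a limit, the starting point is uncertain, and compound 4 may itself fall at the limit. Compound 4 is estimated at 25000 nM, within 8000 nM to 90000 nM.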

Compound 4, half-maximal inhibitory concentration: 34400 nM
For compound 4 the middle estimate is 1.4-fold (0.14 log units) below the measured one; the range from low to high includes it.
By their numbers in this assay, from the lowest: compound 1; then compound 2; then compound 4. At a limit, above all of these: compound 3.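

Compound 3 carries only a limit, and this sets how far the new comparison can go: the limit of > 64000 nM in this assay, at which 1 of the 4 values shown sits. Against that limit, chloro in place of fluoro gives an at least 1.8-fold lower number from compound 3 to compound 4 (0.26 log units; that floor lies within the scatter), so the direction seen on the core of compound 1 may also hold on the core bearing 4-methylphenyl, but the size of the change there remains unknown: the same change on two cores in this assay, a 4.1-fold higher number (0.62 log units; beyond the scatter) from compound 1 to compound 2 and an at least 1.8-fold higher number (0.26 log units; that floor lies within the scatter) from compound 4 to compound 3; the limit leaves it open whether they differ Compound 4 also gives a full measure of the other change with (2-chlorophenyl)amino held constant, where 4-methylphenyl in place of 2-chlorophenyl produces an 18-fold higher number from compound 1 to compound 4 (1.25 log units; beyond the scatter), a large step where the earlier pair gave only a minimum: the same change on two cores in this assay, an at least 7.9-fold higher number (0.89 log units; beyond the scatter) from compound 2 to compound 3 and an 18-fold higher number (1.25 log units; beyond the scatter) from compound 1 to compound 4; the limit leaves it open whether they differ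

With only chloro and fluoro shown at this place on the ring, the compounds leave open how a bromo or a methoxy group would read in this assay. They also leave open whether the two changes act independently of each other, and whether a benzyl group without the 2-chloro or 4-methyl substituent would retain the lower number of compound 1.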